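Saturating the Side Chain of Compound 2

The source may report more compounds than this note shows. Statements on the series, on what has been measured and on what is new or still open speak of the compounds shown alone.

In a functional assay on MCF7 cells (Homo sapiens) for inhibition, read by fluorescence, with a stated time of 72 h (on this read-out higher numbers stand for weaker inhibition of growth and lower numbers for stronger inhibition of growth), compound 1 (`N[C@H]1CC[C@H](Nc2nc(Nc3ccc(Cl)cc3)c3ncn(C4CCCCC4)c3n2)CC1`) gives 2300 nM and compound 2 (`CC(C)=CCn1cnc2c(Nc3cccc(Cl)c3)nc(N[C@H]3CC[C@H](N)CC3)nc21`) gives 4200 nM while compound 3 (`CCCCCCn1cnc2c(Nc3cc(OC)cc(OC)c3)nc(N[C@H]3CC[C@H](N)CC3)nc21`) gives 3500 nM on the same scale. Compound 2 therefore stands within the usual scatter of both other compounds, and these numbers do not separate the three.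

Compound 4 (`CC(C)CCn1cnc2c(Nc3cccc(Cl)c3)nc(N[C@H]3CC[C@H](N)CC3)nc21`) has not been measured yet. It differs from compound 2 in one place: isobutyl takes the place of 2-methylprop-1-en-1-yl on a saturated chain carbon bound to an aromatic nitrogen (isobutyl in place of 2-methylprop-1-en-1-yl on a saturated chain carbon bound to an aromatic nitrogen). For the measured compounds named here, no two measured compounds differ in only one place, so there is no direct precedent for this change. The nearest guide is compound 3, which has a hexyl chain without a double bond in that place and gives 3500 nM in this assay despite also differing from compound 2 elsewhere. This is weak evidence, but it offers no sign that removing the double bond matters much. The expected outcome in this assay is therefore no shift beyond the scatter, in either direction. The step expected here is small (a 1.2-fold lower number from compound 2 to compound 4 (0.08 log units; within the scatter)). For compound 4 the estimated value is 3500 nM (expected range 1800 nM to 7000 nM).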

Compound 4, concentration for 50% growth inhibition: 2100 nM
Estimate against measurement, compound 4: 1.7-fold (0.22 log units) above; measured number inside the range.
By their numbers in this assay, from the lowest: compounds 4, 1, 3 and 2 (each within the scatter of the next).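

For the compounds shown here, compound 2 and compound 4 form the first pair here that differs in only one place, so the double bond in this side chain can be judged directly. In this assay, putting isobutyl in place of 2-methylprop-1-en-1-yl on a saturated chain carbon bound to an aromatic nitrogen gives a 2.0-fold lower number from compound 2 to compound 4 (0.30 log units; within the scatter). At this position, then, the double bond can be removed without a difference that this read-out can separate from ordinary repeat scatter, and no measurement shown here offers an explanation for how the two chains compare.

Compound 1 and compound 3 differ from compound 4 in more than one place, so they cannot show how the chain alone affects the number. This single pair compares only two hydrocarbon chains, which leaves open whether an amine, a carboxylic acid or a longer chain in the same place would move the number beyond the scatter.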